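Alkynyl nucleoside series: chain length and tolerated concentration

This account rests on a few compounds, and the source may have more. Where it says the series, first, only, none or still open, it means among the compounds named here.

Measured so far:
compound 1, `CCCCCCCCCCC#Cc1cc2cn([C@@H]3O[C@H](CO)[C@@H](O)[C@@H]3O)c(=O)nc2o1`: 46000 nM
compound 2, `CCCCCCC#Cc1cc2cn([C@@H]3O[C@H](CO)[C@@H](O)[C@H]3O)c(=O)nc2o1`: >= 133000 nM

Compound 1 gives a number in a functional assay on HEL cells (Homo sapiens) for cytotoxicity; a higher number here means that more compound is tolerated, a lower number that less compound is tolerated. Compound 2 gives only a limit of the assay in this assay, namely >= 133000 nM. Compound 2 therefore stands at the limit of >= 133000 nM in this assay, at which 1 of the 2 values shown sits, and no figure is known for it beyond that. Within the data shown here, compound 1 and compound 2 differ in both the chain and the sugar, so no single step links them, and their two values show only that compound 1 is tolerated at a number while compound 2 sits at the limit.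

Compound 3, `CCCCCCCCCCC#Cc1cc2cn([C@@H]3O[C@H](CO)[C@@H](O)[C@H]3O)c(=O)nc2o1`, differs from compound 2 by butyl in place of hydrogen on a saturated chain carbon, six bonds along the chain from a triple-bonded carbon.

Among the measured compounds shown here, since no step is measured here, the expectation rests on the shape of the two values. Compound 3 carries the same long chain as compound 1, and in this assay compound 1 gives 46000 nM. The step is therefore expected to run toward lower tolerated concentration, an at least 2.4-fold lower number from compound 2 to compound 3 (0.38 log units; beyond the scatter), beyond the scatter. Compound 3 is estimated at 55000 nM, within 20000 nM to 133000 nM.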

Compound 3, minimum cytotoxic concentration: 12000 nM
Compound 3: middle estimate off by 4.6-fold (0.66 log units), on the high side; measured number below the stated range.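

In this assay, butyl in place of hydrogen on a saturated chain carbon, six bonds along the chain from a triple-bonded carbon, gives a step that can be read in a single place: an at least 11-fold lower number from compound 2 to compound 3 (1.04 log units; beyond the scatter). Compound 2 enters that step as a limit of the assay and not as a number, so the true size of the step is not fixed: the limit of >= 133000 nM in this assay, at which 1 of the 3 values shown sits. With the chain held, a stereocentre at a saturated ring carbon also shifts the read-out in this assay, giving a 3.8-fold lower number from compound 1 to compound 3 (0.58 log units; beyond the scatter), and this step can be set on configuration alone: the fact that compounds 1 and 3 differ only in the configuration as drawn.

Still open, on these data alone, is whether the tolerated concentration keeps falling with a longer chain than that of compound 3, and whether any chain length between those of compound 2 and compound 3 marks the point where a number replaces the limit. Also open, as far as these compounds go, are whether the configuration step holds at the shorter chain of compound 2, and how an amine or a carboxylic acid carried on the chain would read in this assay.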